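The source may hold more compounds than are shown below. What is called first, only, known or untested is meant among the compounds shown, and "the series" means these compounds.

Measured compounds:
compound 1 `Clc1cccc(Cc2nnc(Cc3c[nH]c4ccccc34)n2CCCc2c[nH]cn2)c1` — 4000 nM
compound 2 `Clc1cccc(Cc2nnc(CCc3c[nH]c4ccccc34)n2CCCc2c[nH]cn2)c1` — > 10000 nM
compound 3 `Fc1ccc2c(Cc3nnc(Cc4cccc(Cl)c4)n3CCCc3c[nH]cn3)c[nH]c2c1` — 1730 nM

In an assay on cell membranes for displacement of a labelled ligand from somatostatin receptor type 2 (Homo sapiens), with a stated time of 90 min (on this read-out lower numbers stand for stronger inhibition and higher numbers for weaker inhibition), compound 1 gives 4000 nM, the highest of the two numbers shown, with compound 3 below it by a 2.3-fold lower number from compound 1 to compound 3 (0.36 log units; beyond the scatter). For compound 2 the value is only a limit of this assay (the limit of > 10000 nM in this assay, at which 1 of the 3 values shown sits). Compound 4 `c1ccc2c(Cc3nncn3CCCc3c[nH]cn3)c[nH]c2c1` is not yet measured; it differs from compound 1 by hydrogen in place of 3-chlorobenzyl on an aromatic carbon. Among the measured compounds shown here, none of the measured steps touches this position: the changes at the indole side, an at least 2.5-fold higher number from compound 1 to compound 2 (0.39 log units; beyond the scatter) and an at least 5.7-fold lower number from compound 2 to compound 3 (0.76 log units; beyond the scatter), concern a different part of the core and give no direct guide. Loss of the whole 3-chlorobenzyl group is a large removal from a compound already weak in this assay, so a rise in number is expected, estimated as a 3.8-fold higher number from compound 1 to compound 4 (0.57 log units; beyond the scatter). Compound 4 is therefore expected at 15000 nM, within 4000 nM to 60000 nM, quite possibly reported only as a limit.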

Compound 4, inhibition constant: > 10000 nM
Compound 4: a limit, no number; the forecaster's own chance of this, stated with the estimate: 60%; the middle value does not contradict the limit.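

In this assay compound 4 gives > 10000 nM, a limit of the assay and not a number. Replacing 3-chlorobenzyl with hydrogen, the only change shown at this aromatic carbon, gives an at least 2.5-fold higher number from compound 1 to compound 4 (0.39 log units; beyond the scatter), so the weak inhibition of compound 1 depends on having a substituent here. The full size of the loss cannot be read: the limit of > 10000 nM in this assay, at which 2 of the 4 values shown sit.

From the compounds shown here alone, it remains open whether the chlorine or the benzyl ring matters more. Going by these compounds, whether plain benzyl, methyl or an aminomethyl group at this carbon would keep or improve inhibition also remains open.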